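Aziridinyl quinone series: carbamate chain replaced by methoxypropyl

The source may hold more compounds than are shown below. What is called first, only, known or untested is meant among the compounds shown, and "the series" means these compounds.

The shared core carries two aziridin-1-yl groups and a carbamate-terminated chain in compound 1 `CC1=C(N2CC2)C(=O)C(CCCOC(N)=O)=C(N2CC2)C1=O`, compound 2 `CCC1=C(N2CC2)C(=O)C(CCOC(N)=O)=C(N2CC2)C1=O` and compound 3 `CCCC1=C(N2CC2)C(=O)C(CCOC(N)=O)=C(N2CC2)C1=O`. In a functional assay on L1210 cells (Mus musculus), with a stated time of 1 days (on this read-out lower numbers stand for lower potency and higher numbers for higher potency (the scale is a negative logarithm)), compound 1 gives 5.55, the second highest of the three numbers. Compound 2 gives 5.98, beyond the scatter above compound 1, and compound 3 gives 4.9, beyond the scatter below it. For the measured compounds named here, the one measured single-point step, a number 1.08 log units lower from compound 2 to compound 3 (beyond the scatter), is methyl in place of hydrogen on a saturated chain carbon two bonds along the chain from a double-bonded ring carbon.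

Compound 4 `CCC(OC)C1=C(N2CC2)C(=O)C(C)=C(N2CC2)C1=O` is reached from compound 1 by a group of 5 heavy atoms (4 carbon, 1 oxygen; no ring) in place of a group of 7 heavy atoms (4 carbon, 1 nitrogen, 2 oxygen; no ring), on a double-bonded ring carbon. Going by the values given here, no measured step touches this side of the core or removes the carbamate, so no step bears on it directly. Among the compounds with values here, the only step available shows that enlarging a group on the core lowered this assay strongly, and compound 4 both drops the hydrogen-bond donor and changes the chain, so a downward step is expected rather than none. The estimate for compound 4 is 4.9, with a range from 4.2 to 5.6, meaning an expected step of a number 0.65 log units lower from compound 1 to compound 4 (beyond the scatter).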

Compound 4, logarithm of the reciprocal of the active concentration, log(1/C): 5.26
Beside the measured number, compound 4's estimate is 0.36 log units below it, and the stated range covers the measured number.
By their numbers in this assay, from the lowest: compound 3; then compounds 4 and 1 (each within the scatter of the next); then compound 2.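

In this assay there is a number 0.29 log units lower from compound 1 to compound 4 (within the scatter), so on this double-bonded ring carbon the 1-methoxypropyl group and the carbamate-ending group of 7 heavy atoms cannot be told apart on this read-out. The exchange removes the nitrogen, the hydrogen-bond donor and one hydrogen-bond acceptor of the leaving group, and the number stays within the scatter, so the carbamate is not needed for a value in this range when the ring atom three ring bonds away bears a methyl group. For the compounds shown here, the earlier compounds gave no view of this: their only single-point step, a number 1.08 log units lower from compound 2 to compound 3 (beyond the scatter), concerns methyl in place of hydrogen on a saturated chain carbon and leaves the carbamate in place. No measurement in hand offers an explanation for this result.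

Still open, as far as these compounds go, is whether a primary amine or a carboxylic acid at the end of a chain on this ring carbon would also stay within the scatter of compound 1. From the compounds shown here alone, it is equally open whether the 1-methoxypropyl group would give a similar number with an ethyl group in place of the methyl group, the ring substituent of compound 2.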